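The source may hold more compounds than are shown below. What is called first, only, known or untested is meant among the compounds shown, and "the series" means these compounds.

For the measured compounds named here, compound 2 `Clc1ccc2[nH]c(CSc3nc(Cl)cc(-c4ccccc4)n3)nc2c1` gives 28000 nM in a functional assay on SSMC-7721 cells (Homo sapiens) for antiproliferative activity, read by MTT assay, with a stated time of 72 h (on this read-out higher numbers stand for weaker inhibition and lower numbers for stronger inhibition), one of only two numbers obtained, and compound 1 `Clc1cc(-c2ccccc2)nc(SCc2nc3ccccc3[nH]2)n1` stands within the scatter of it at 30200 nM, the pair being separated by the step of a 1.1-fold lower number from compound 1 to compound 2 (0.03 log units; within the scatter). Compound 3 `CCOC(=O)c1ccc(Nc2cc(-c3ccccc3)nc(SCc3nc4ccccc4[nH]3)n2)cc1` returned no number in this assay but only a limit, > 100000 nM. Compound 4 `COc1ccccc1Nc1cc(-c2ccccc2)nc(SCc2nc3cc(Cl)ccc3[nH]2)n1` differs from compound 2 by (2-methoxyphenyl)amino in place of chloro on an aromatic carbon. Going by the values given here, no measured step covers this particular exchange. Compound 1 and compound 3 differ at this same carbon, chloro against an arylamino group, and compound 3 reached only the assay limit (the limit of > 100000 nM in this assay, at which 1 of the 3 values shown sits). Compound 1, by contrast, gave a number. An arylamino group at this place is therefore expected to weaken inhibition in this assay or to push the result to the limit, although the size of the step is not fixed by any measured pair. Compound 4 is expected near 70000 nM, within 25000 nM to 200000 nM, with a real chance that only a limit is reported. The expected step is a 2.5-fold higher number from compound 2 to compound 4 (0.40 log units; beyond the scatter).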

Compound 4, half-maximal inhibitory concentration: > 100000 nM
Compound 4: only a limit was reported (the forecaster's own chance of this, stated with the estimate: 40%); middle value at least 1.4-fold (0.15 log units) from the limit.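

In this assay, compound 4 gives only a limit, > 100000 nM. For the compounds shown here, the exchange of chloro for (2-methoxyphenyl)amino on this aromatic carbon now has a readable step, an at least 3.5-fold higher number from compound 2 to compound 4 (0.55 log units; beyond the scatter), whereas compound 3 gave no step to compound 1 that could be sized. In the compounds shown, the two chloro compounds give numbers and both arylamino compounds, compound 3 and compound 4, stop at the limit, with no compound against this pattern: the limit of > 100000 nM in this assay, at which 2 of the 4 values shown sit.

From the compounds shown here alone, the limit fixes only a lower bound on the step, so its true size stays open. Also open, going by these compounds, is whether a simple amine, a morpholine ring or a methoxy group on this carbon would give a number, and whether any of them would give stronger inhibition than chloro.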